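This account rests on a few compounds, and the source may have more. Where it says the series, first, only, none or still open, it means among the compounds named here.

Working notes on the series, read in a functional assay on HeLa cells (Homo sapiens) for cytotoxicity, read by MTT assay, with a stated time of 48 h (on this read-out lower numbers stand for stronger inhibition and higher numbers for weaker inhibition), and based on three measured compounds. Compound 1 (`COc1cc(/C=C/C(=O)C2=C(/C=C/c3ccc(O)c(OC)c3)NC(=O)NC2c2cccc([N+](=O)[O-])c2)ccc1O`) gives 100000 nM in this assay as its value. Compound 2 (`COc1cc(/C=C/C(=O)C2=C(/C=C/c3ccc(O)c(OC)c3)NC(=S)NC2c2ccccc2)ccc1O`) gives 25000 nM as its value. Compound 3 (`COc1cc(/C=C/C(=O)C2=C(/C=C/c3ccc(O)c(OC)c3)NC(=S)NC2c2ccc(N(C)C)cc2)ccc1O`) gives 12500 nM as its value, which lies within the scatter of compound 2 and well under the value of compound 1.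

The next entry is compound 4 (`COc1cc(/C=C/C(=O)C2=C(/C=C/c3ccc(O)c(OC)c3)NC(=S)NC2c2ccccc2Cl)ccc1O`). The change from compound 3 is 2-chlorophenyl in place of 4-(dimethylamino)phenyl on a saturated ring carbon, counted as follows: 2-chlorophenyl in place of 4-(dimethylamino)phenyl on a saturated ring carbon.

Within the data shown here, only one measured step concerns this aromatic group, namely a 2.0-fold lower number from compound 2 to compound 3 (0.30 log units; within the scatter), where dimethylamino replaces hydrogen on an aromatic carbon. That step stays within the scatter. Among the measured compounds shown here, no measured compound carries chlorine, so the data offer no direct guide to it. On these data alone, no step beyond the scatter is therefore expected in this assay, and the direction remains open.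

The expected step is a 1.4-fold higher number from compound 3 to compound 4 (0.16 log units; within the scatter). Compound 4 is estimated at 18000 nM, with an expected range from 6000 nM to 55000 nM.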

Compound 4, half-maximal inhibitory concentration: 50000 nM
Compound 4: middle estimate off by 2.8-fold (0.44 log units), on the low side; low and high end bracket the measured number.
By their numbers in this assay, from the lowest: compounds 3, 2, 4 and 1 (each within the scatter of the next, the first and the last beyond it).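

In this assay this position gives its first step beyond the scatter, a 4.0-fold higher number from compound 3 to compound 4 (0.60 log units; beyond the scatter), so the choice between 2-chlorophenyl and 4-(dimethylamino)phenyl on the saturated ring carbon can be read in this assay. Measured against the unsubstituted phenyl group, both single substitutions stay within the scatter, chloro with a 2.0-fold higher number from compound 2 to compound 4 (0.30 log units; within the scatter) and dimethylamino with a 2.0-fold lower number from compound 2 to compound 3 (0.30 log units; within the scatter), so compounds 3 and 4 separate from each other while neither separates from compound 2. The data shown offer no measurement that explains this gap.

Open, on these data alone, is how a carboxylic acid or a primary amine in place of dimethylamino would read at this position. Compound 1 differs from the others in more than one place, so the effect of the ring carbonyl against its sulfur counterpart cannot be separated from that of the nitro-bearing aromatic group.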